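The compounds below may be only part of what the source reports. "The series", "measured", "known", "first", "only" and "open" are said of these compounds alone.

Compound 1 `COc1cc2c(cc1OC)C(CC(=O)O)CC2` is the acid of this small series. In a functional assay on the whole organism (strain Wistar) for inhibition, with Rattus norvegicus as the target, read by paw edema, with stated times of 60 min and 1 h, at a dose of 100 mg/kg by the oral route (on this read-out higher numbers stand for more inhibition at the one dose given (going by the name of the read-out) and lower numbers for less inhibition), compound 1 gives 18.8%, which places it, together with compound 2, at the bottom of the three numbers. Compound 2 `COc1cc2c(cc1OC)C(CC(N)=O)CC2` gives 18.8% in this assay, and the step of no change at the digits printed from compound 1 to compound 2 (within the scatter) shows that amino in place of hydroxy on the carbonyl carbon leaves the read-out where it was. Compound 3 `CCN(CC)C(=O)CC1CCc2cc(OC)c(OC)cc21` gives 31.3%, so that a number 12.5 percentage points higher from compound 1 to compound 3 (beyond the scatter) and a number 12.5 percentage points higher from compound 2 to compound 3 (beyond the scatter) both mark a modest rise once diethylamino sits on the carbonyl carbon.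

Compound 4 `COc1cc2c(cc1OC)C(CC(=O)N1CCOCC1)CC2` differs from compound 1 as follows: morpholin-4-yl in place of hydroxy on a carbonyl carbon. The step of a number 12.5 percentage points higher from compound 1 to compound 3 (beyond the scatter) bears most closely on it, since there too a group with no hydrogen-bond donor replaced hydroxy on the same carbonyl carbon, whereas no change at the digits printed from compound 1 to compound 2 (within the scatter) shows that not every such exchange moves the number. A modest upward step is therefore expected for compound 4, roughly a number 9.2 percentage points higher from compound 1 to compound 4 (within the scatter). In this assay compound 4 is estimated at 28%, within a range from 14% to 42%.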

Compound 4, a percentage reported as inhibition, in the whole organism at one dose (the size of the read-out at that dose, not a potency): 15.6%
For compound 4 the middle estimate is 12.4 percentage points above the measured one, within the range that was stated.
By their numbers in this assay, from the lowest: compounds 4, 1 and 2 (each within the scatter of the next); then compound 3.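

In this assay, morpholin-4-yl on the carbonyl carbon does not bring the rise seen with diethylamino: a number 3.2 percentage points lower from compound 1 to compound 4 (within the scatter) and a number 3.2 percentage points lower from compound 2 to compound 4 (within the scatter) both stay within the scatter, whereas a number 15.7 percentage points lower from compound 3 to compound 4 (beyond the scatter) lies beyond it. Compound 3 and compound 4 both carry no hydrogen-bond donor on this carbonyl carbon, yet only compound 3 stands apart from compound 1, so the absence of a donor alone does not set the number at this position. Nothing available here accounts for the difference between these two groups.

As far as these compounds go, it remains open whether piperidin-1-yl, a six-membered ring without the ring oxygen, would stand with diethylamino or with morpholin-4-yl. The compounds shown also leave open how dipropylamino would fare on the same carbonyl carbon.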